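This account rests on a few compounds, and the source may have more. Where it says the series, first, only, none or still open, it means among the compounds named here.

Compound 1 `Cc1cccc2c1N(Cc1ccccc1)C(=O)C21C(C#N)=C(N)Oc2cc3oc(-c4ccccc4)cc(=O)c3c(O)c21`: in a functional assay on PC-3 cells (Homo sapiens) for antiproliferative activity, read by MTT assay, with a stated time of 48 h (on this read-out higher numbers stand for weaker inhibition and lower numbers for stronger inhibition), compound 1 gives > 50000 nM, which is a limit of the assay.
Compound 2 `N#CC1=C(N)Oc2cc3oc(-c4ccccc4)cc(=O)c3c(O)c2C12C(=O)N(Cc1ccccc1)c1ccc(Cl)cc12`: in this assay compound 2 gives > 50000 nM, which is a limit of the assay.
Compound 3 `N#CC1=C(N)Oc2cc3oc(-c4ccccc4)cc(=O)c3c(O)c2C12C(=O)N(Cc1ccccc1)c1c(Cl)cccc12`: in this assay compound 3 gives > 50000 nM, which is a limit of the assay.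

Compound 3 therefore stands at the limit in this assay, and it shares that position with every other compound shown, since (the limit of > 50000 nM in this assay, at which 3 of the 3 values shown sit). For the measured compounds named here, the single step between measured compounds that differ in one place, from compound 1 to compound 3, is a step that the two limits leave unreadable from compound 1 to compound 3, so its size is not known.

Compound 4 `N#CC1=C(N)Oc2cc3oc(-c4ccccc4)cc(=O)c3c(O)c2C12C(=O)Nc1c(Cl)cccc12` differs from compound 3 by hydrogen in place of benzyl on an amide-type nitrogen in a ring. Going by the values given here, no measured step bears on this change: the only step recorded is unreadable, and none of the three compounds carries a change at this nitrogen. The data give no ground to expect that compound 4 would leave the limit.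

The step from compound 3 to compound 4 is therefore expected to be a step that the limit leaves unreadable from compound 3 to compound 4, meaning no change that could be read. Compound 4 is estimated at 80000 nM in this assay, within a range from 20000 nM to 300000 nM, and most likely it will again be reported only as a limit.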

Compound 4, half-maximal inhibitory concentration: > 50000 nM
Compound 4 was reported as a limit; the forecaster's own chance of this, stated with the estimate: 85%; the middle value lies beyond the limit too.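

The step from compound 3 to compound 4 cannot be read, and no new step emerges, since both compounds sit at the same limit: the limit of > 50000 nM in this assay, at which 4 of the 4 values shown sit.

The compounds shown leave open whether any change on the shared core moves activity in this assay, and by how much.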